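The source may hold more compounds than are shown below. What is called first, only, known or untested is meant among the compounds shown, and "the series" means these compounds.

Compound 1 `O=S(=O)(Nc1ccc(-c2nc3ccccc3o2)cc1)c1ccc(Cl)c(C(F)(F)F)c1` was tested in an assay on isolated protein for inhibition of malate dehydrogenase, mitochondrial (Sus scrofa), with stated times of 45 min and 30 min; on this read-out lower numbers stand for stronger inhibition and higher numbers for weaker inhibition. In this assay compound 1 gives > 63000 nM, which is a limit of the assay and not a measured number. Compound 2 `O=S(=O)(Nc1ccc(-c2nc3ccccc3o2)cc1)c1ccc(Cl)s1` gives in this assay > 63000 nM, again only a limit. Compound 3 `O=S(=O)(Nc1ccc(-c2nc3ccccc3o2)cc1)c1ccc(F)c(C(F)(F)F)c1` gives in this assay > 63000 nM, also a limit. Compound 1 therefore stands only at a limit, and so do the other two, as the limit of > 63000 nM in this assay, at which 3 of the 3 values shown sit, shows. The change from compound 1 to compound 3, fluoro in place of chloro on an aromatic carbon, gives a step that the two limits leave unreadable from compound 1 to compound 3, so its size is hidden by the two limits.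

Compound 4 `O=[N+]([O-])c1cc(S(=O)(=O)Nc2ccc(-c3nc4ccccc4o3)cc2)ccc1Cl` differs from compound 1 by nitro in place of trifluoromethyl on an aromatic carbon. Going by the values given here, no measured step resembles this change, and the only step at hand is unreadable. With every measured compound sitting at the limit, compound 4 is expected to sit there too, meaning an expected step that the limit leaves unreadable from compound 1 to compound 4 that cannot be read beyond the scatter. The estimate for compound 4 in this assay is 100000 nM, with a range from 30000 nM to 400000 nM.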

Compound 4, half-maximal inhibitory concentration: > 63000 nM
Compound 4: no number, only a limit; the forecaster's own chance of this, stated with the estimate: 85%; the middle value lies beyond the limit too.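

Going by these compounds alone, no step from compound 1 to compound 4 can be read, because both stand only at a limit of the assay, not at a number: the limit of > 63000 nM in this assay, at which 4 of the 4 values shown sit. The compounds shown leave open how strongly any of them inhibits the enzyme and whether these group changes alter that strength at all.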